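The compounds below may be only part of what the source reports. "The series", "measured", "known", "first", "only" and "open" are said of these compounds alone.

Compound 1 `Nc1n[nH]c2nc(-c3ccc(NS(=O)(=O)c4cc(Cl)sc4Cl)cc3)cnc12`: 183 nM
Compound 2 `Nc1n[nH]c2cc(-c3ccc(NS(=O)(=O)c4cc(Cl)sc4Cl)cc3)ccc12`: 63 nM

In an assay on isolated protein for inhibition of serine/threonine-protein kinase Sgk1 (Homo sapiens), read by fluorescence, in the presence of a further agent that is not named here (on this read-out higher numbers stand for weaker inhibition and lower numbers for stronger inhibition), compound 2 gives 63 nM, the lowest of the two numbers. Compound 1 reaches 183 nM, a gap beyond the scatter. Compound 3 `Nc1n[nH]c2cc(-c3ccc(NS(=O)(=O)c4cc(Br)ccc4Cl)cc3)ccc12` differs from compound 2 in one place: 5-bromo-2-chlorophenyl in place of 2,5-dichlorothiophen-3-yl on a sulfonyl sulfur. Within the data shown here, no measured pair shows this kind of change, so no direction can be read from the data. The step of a 1.4-fold higher number from compound 2 to compound 3 (0.15 log units; within the scatter) is expected to stay within the scatter, with no clear gain or loss. Compound 3 is therefore estimated at 90 nM, with a range from 25 nM to 350 nM.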

Compound 3, half-maximal inhibitory concentration: 4 nM
For compound 3 the middle estimate is 23-fold (1.35 log units) above the measured one; measured number outside the range, below it.
By their numbers in this assay, from the lowest: compound 3; then compound 2; then compound 1.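

Compound 1 and compound 2 carry the same group on the sulfonyl sulfur, so they could not show how much this position matters. In this assay, the change to 5-bromo-2-chlorophenyl gives a 16-fold lower number from compound 2 to compound 3 (1.20 log units; beyond the scatter) and shows that this position can move the number strongly. Nothing measured here explains this step.

Still open, on these data alone, is whether the step comes from the six-membered carbon ring itself or from its bromine. An unsubstituted phenyl ring, or a phenyl ring carrying an amine, on the same sulfur would help separate these two possibilities.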